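Hepatocyte clearance notes on the shared-core series, step to compound 4

The source may hold more compounds than are shown below. What is called first, only, known or untested is meant among the compounds shown, and "the series" means these compounds.

Measured so far:
compound 1 `CN(C)C(=O)CN1CCC(c2cc3c(-c4ccc(=O)n(C5CCC5)c4)ccnc3[nH]2)CC1`: 5.8 uL/min
compound 2 `CC(C)n1cc(-c2ccnc3[nH]c(C4CCN(CC(=O)N5CCCCC5)CC4)cc23)ccc1=O`: 26 uL/min
compound 3 `Cc1nc2ccc(-c3ccnc4[nH]c(C5CCN(CC(=O)N(C)C)CC5)cc34)cc2n1C(C)C`: 10 uL/min

In an ADME assay on cells (Hepatocyte, Rattus norvegicus) for metabolic stability (on this read-out higher numbers stand for fast clearance and lower numbers for slow clearance), compound 2 gives 26 uL/min, the highest of the three numbers; compound 3 sits nearest, and compound 1 furthest, both beyond the scatter. Compound 4 `CNC(=O)CN1CCC(c2cc3c(-c4ccc(=O)n(C(C)C)c4)ccnc3[nH]2)CC1` is not yet measured. It differs from compound 2 in one place: methylamino in place of piperidin-1-yl on a carbonyl carbon. Compound 1 and compound 3 both carry a smaller group on that carbonyl carbon and both give lower numbers than compound 2, so a downward step is expected for compound 4, roughly a 2.9-fold lower number from compound 2 to compound 4 (0.46 log units; beyond the scatter), beyond the scatter. Compound 4 is thus estimated at 9 uL/min, within 4.5 uL/min to 18 uL/min.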

Compound 4, intrinsic clearance in a liver preparation (reported as CLH), per the amount of preparation that the assay uses: 8.9 uL/min
Compound 4: middle estimate off by 1.0-fold (0.00 log units), on the high side; the measured number falls inside the stated range.
By their numbers in this assay, from the lowest: compounds 1, 4 and 3 (each within the scatter of the next); then compound 2.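

In this assay the series gains its first single-place comparison: methylamino in place of piperidin-1-yl on a carbonyl carbon gives a 2.9-fold lower number from compound 2 to compound 4 (0.47 log units; beyond the scatter) with the rest of the structure unchanged. Within the data shown here, compound 1 and compound 3 each differ from compound 2 in more than one place, so only this step ties a change beyond the scatter to this position. No data on hand bear on the cause of the step.

Going by these compounds, whether the loss of the ring, the smaller group or the amide hydrogen carries the step stays open. Ethylamino or morpholin-4-yl on this carbonyl carbon would help separate these.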